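Thieno-fused aminopyrimidine series: aryl swap at the ring carbon

The source may hold more compounds than are shown below. What is called first, only, known or untested is meant among the compounds shown, and "the series" means these compounds.

Measured compounds in a functional assay on CHO-K1 cells for antagonist activity at adenosine receptor A1 (Homo sapiens), read by a beta-galactosidase reporter and cAMP accumulation, with stated times of 15 min and 6 h; on this read-out higher numbers stand for weaker inhibition and lower numbers for stronger inhibition:
compound 1 `Nc1nc(-c2ccc(C(F)F)o2)nc2sc(Cc3ccccc3)cc12`, 3000 nM
compound 2 `COc1ccccc1Cc1cc2c(N)nc(-c3ccc(C(F)F)o3)nc2s1`, 516 nM

Within the data shown here, compound 1 has the highest number of the two; the only neighbour is compound 2, reached by a 5.8-fold lower number from compound 1 to compound 2 (0.76 log units; beyond the scatter), a change at the benzyl group that does not touch the aryl ring on the shared core.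

Compound 3 `Nc1nc(-c2ccccc2)nc2sc(Cc3ccccc3)cc12` is not yet measured. It differs from compound 1 by phenyl in place of 5-(difluoromethyl)furan-2-yl on an aromatic carbon. The place is on an aromatic carbon of a six-membered aromatic ring with 2 nitrogen, between two ring nitrogen atoms, para to a fused ring and meta to an amino group.

Among the measured compounds shown here, no measured step bears on this change: the single step from compound 1 to compound 2 alters the benzyl group and not the aryl substituent, so it gives no guide to what the loss of the 5-(difluoromethyl)furan-2-yl and the entry of phenyl will do. The expectation for compound 3 in this assay therefore rests on compound 1 alone, with a wide range and no confident direction; a step of a 1.7-fold higher number from compound 1 to compound 3 (0.22 log units; within the scatter) is estimated, possibly toward a weaker number. Compound 3 is estimated at 5000 nM, within 1500 nM to 20000 nM.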

Compound 3, inhibition constant: 151 nM
The estimate for compound 3 lay 33-fold (1.52 log units) above the measured number; the whole stated range lies above it.
By their numbers in this assay, from the lowest: compound 3; then compound 2; then compound 1.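

In this assay, the aromatic carbon between two ring nitrogen atoms proves sensitive to the group it carries: phenyl in place of 5-(difluoromethyl)furan-2-yl gives a 20-fold lower number from compound 1 to compound 3 (1.30 log units; beyond the scatter) on an otherwise unchanged structure. This is the first reading at this position, and its step is labelled large, whereas the change on the benzyl group, a 5.8-fold lower number from compound 1 to compound 2 (0.76 log units; beyond the scatter), is labelled modest, so among the two changes shown the aryl swap moves the number further. Nothing available bears on why the phenyl compound gives the lower number.

The swap replaces the ring and removes the difluoromethyl group in a single change, so the two contributions cannot be separated; a plain furan-2-yl or a pyridine ring at this carbon would help to tell them apart. Going by these compounds, compound 2 and compound 3 differ in two places, so whether the methoxy on the benzyl group and phenyl on the shared core combine remains open, and the compound carrying both groups would answer that directly.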